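Aryl in place of cyclohexyl on the amine: working notes

The source may report more compounds than this note shows. Statements on the series, on what has been measured and on what is new or still open speak of the compounds shown alone.

Values so far in a functional assay on MGC-803 cells (Homo sapiens) for inhibition, read by sulforhodamine B assay; on this read-out higher numbers stand for weaker inhibition and lower numbers for stronger inhibition:
compound 1 `O=C1C(Nc2ccccc2F)=CC(=O)c2c1nc1n2[C@H]2OC[C@@H](O)[C@H]2OC1`: 2000 nM
compound 2 `O=C1C(NC2CCCC2)=CC(=O)c2c1nc1n2[C@H]2OC[C@@H](O)[C@H]2OC1`: > 16000 nM (a limit)
compound 3 `O=C1C=C(NC2CCCCC2)C(=O)c2c1nc1n2[C@H]2OC[C@@H](O)[C@H]2OC1`: > 8000 nM (a limit)

Compound 3 stands at > 8000 nM and that is a limit and not a number. Compound 2 gives > 16000 nM and that is also a limit. Compound 4 `O=C1C=C(Nc2ccc(C(F)(F)F)cc2)C(=O)c2c1nc1n2[C@H]2OC[C@@H](O)[C@H]2OC1` has not yet been measured in this assay and keeps the core of compound 3. The change is 4-(trifluoromethyl)phenyl in place of cyclohexyl on an amine nitrogen with 4-(trifluoromethyl)phenyl in place of cyclohexyl on an amine nitrogen.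

Among the compounds with values here, one measured step bears on this: an at least 8.0-fold higher number from compound 1 to compound 2 (0.90 log units; beyond the scatter) with cyclopentyl in place of 2-fluorophenyl. Read in reverse, that step points to a lower number when an aromatic ring replaces a saturated ring. The transfer is loose: the amine is attached differently on the core of compound 1 and the core of compound 3, and the two aromatic groups are not the same. A modest move toward stronger inhibition is therefore expected, with a real chance of no number at all. The expected change is an at least 2.6-fold lower number from compound 3 to compound 4 (0.42 log units; beyond the scatter) in this assay as a working estimate. For compound 4 the estimated value is 3000 nM with an expected range from 800 nM to 11000 nM in this estimate.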

Compound 4, half-maximal inhibitory concentration: 2820 nM
Beside the measured number, compound 4's estimate is 1.1-fold (0.03 log units) above it; measured number inside the range.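

In this assay, 4-(trifluoromethyl)phenyl in place of cyclohexyl on the amine nitrogen gives an at least 2.8-fold lower number from compound 3 to compound 4 (0.45 log units; beyond the scatter), so the core of compound 3 now has a measured number among the compounds shown. The size of this step is only a lower bound, as compound 3 stands at a limit and not a number: the limit of > 8000 nM in this assay, at which 1 of the 4 values shown sits. The earlier step from an aromatic ring to a saturated ring lay on the core of compound 1, and this step shows the same direction on a second core, with no compound shown going against it.

As far as these compounds go, it stays open whether the step belongs to the aromatic ring itself or to the trifluoromethyl group, a question that plain phenyl or 4-methoxyphenyl on the same amine nitrogen of the core of compound 3 would address. Also open, from the compounds shown here alone, are the full size of the step and whether a nitrile or a carboxylic acid in place of the trifluoromethyl group would keep a measurable value in this assay.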